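The compounds below may be only part of what the source reports. "The series", "measured", "known", "first", "only" and "open" are said of these compounds alone.

In an ADME assay on NIH3T3 cells (Homo sapiens) for cytotoxicity, read by sulforhodamine B assay, with a stated time of 48 h (on this read-out higher numbers stand for weaker inhibition and lower numbers for stronger inhibition), three compounds have been measured. Compound 1, with the structure `CC(=O)OC[C@H]1O[C@@H](n2cc(Cn3cc(/C=C/C(=O)c4cccnc4)c4ccccc43)nn2)[C@H](OC(C)=O)[C@@H](OC(C)=O)[C@@H]1OC(C)=O`, reached only a limit of the measurement: in this assay compound 1 gives > 200000 nM, which is a limit and not a number. Compound 2, with the structure `CC(=O)OC[C@H]1O[C@@H](n2cc(CN3C(=O)/C(=C\C=C\c4ccccc4)c4ccccc43)nn2)[C@H](OC(C)=O)[C@@H](OC(C)=O)[C@@H]1OC(C)=O`, gives 25900 nM in this assay. Compound 3, with the structure `CC(=O)OC[C@H]1O[C@@H](n2cc(CN3C(=O)/C(=C/C=C/c4ccccc4)c4ccccc43)nn2)[C@H](OC(C)=O)[C@@H](OC(C)=O)[C@@H]1OC(C)=O`, gives 12300 nM in this assay. Compounds 2 and 3 share every atom and bond and differ only in how one double bond is drawn, and the step of a 2.1-fold lower number from compound 2 to compound 3 (0.32 log units; beyond the scatter) is a modest move beyond the scatter. Among the two numbers shown, compound 3 stands at the lower end, with compound 2 the nearest.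

Compound 4, with the structure `CC(=O)OC[C@H]1O[C@@H](n2cc(CN3C(=O)/C(=C/c4ccc5ccccc5c4)c4ccccc43)nn2)[C@H](OC(C)=O)[C@@H](OC(C)=O)[C@@H]1OC(C)=O`, has not yet been measured. It differs from compound 3 by the change (naphthalen-2-yl in place of 2-phenylethenyl on a double-bonded chain carbon bound to a double-bonded ring carbon). Within the data shown here, the only measured step concerns a change in double-bond geometry, not an exchange of one carbon group for another, so no measured step bears directly on this exchange. With so little to lean on, the expected step of a 1.0-fold lower number from compound 3 to compound 4 (0.01 log units; within the scatter) is one that stays within the scatter. For compound 4 the estimated value in this assay is 12000 nM, with a range from 4000 nM to 40000 nM.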

Compound 4, half-maximal inhibitory concentration: 28400 nM
Estimate against measurement, compound 4: 2.4-fold (0.37 log units) below; measured number inside the range.
By their numbers in this assay, from the lowest: compound 3; then compounds 2 and 4 (each within the scatter of the next). At a limit, above all of these: compound 1.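

Until now this position, on a double-bonded chain carbon bound to a double-bonded ring carbon, had been probed only by changing double-bond geometry, while the group itself stayed 2-phenylethenyl. Exchanging that group for naphthalen-2-yl gives a 2.3-fold higher number from compound 3 to compound 4 (0.36 log units; beyond the scatter) in this assay, so the group at this place also affects the read-out, and here the exchange goes towards weaker inhibition, though only modestly. Nothing measured here explains why the number rises, since neither fact on record concerns this exchange.

The exchange changes several things at once: it adds a second six-membered aromatic ring and removes the double bond outside aromatic rings, so this one step cannot separate the two changes. The compounds shown leave open how a plain phenyl group placed directly at this position would behave, whether an amine or a carboxylic acid on the aromatic ring would move the number in either direction, and whether the opposite double-bond geometry would alter the value of compound 4.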